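A Furan-to-Thiophene Swap Retested on a Chlorinated Core

The source may hold more compounds than are shown below. What is called first, only, known or untested is meant among the compounds shown, and "the series" means these compounds.

The study compares three measured compounds and one that awaits its number. Compound 1 `OC[C@H]1O[C@@H](n2cc(F)c3c(-c4ccoc4)ncnc32)[C@H](O)[C@@H]1O` gives 170 nM in a functional assay on HeLa S3 cells (Homo sapiens) for cytotoxicity, read by XTT assay, with a stated time of 3 days; a lower number here means a stronger inhibitor, a higher number a weaker inhibitor. Compound 2 `OC[C@H]1O[C@@H](n2cc(F)c3c(-c4ccsc4)ncnc32)[C@H](O)[C@@H]1O` gives 210 nM in this assay, and compound 3 `OC[C@H]1O[C@@H](n2cc(Cl)c3c(-c4ccoc4)ncnc32)[C@H](O)[C@@H]1O` gives 2700 nM in this assay.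

The change from compound 1 to compound 2 is thiophen-3-yl in place of furan-3-yl on an aromatic carbon. It made a 1.2-fold higher number from compound 1 to compound 2 (0.09 log units; within the scatter). The change from compound 1 to compound 3 is chloro in place of fluoro on an aromatic carbon; this is also how the core of compound 3 differs from the core of compound 1. It made a 16-fold higher number from compound 1 to compound 3 (1.20 log units; beyond the scatter), and compound 3 stands with the highest number of the three.

Compound 4 `OC[C@H]1O[C@@H](n2cc(Cl)c3c(-c4ccsc4)ncnc32)[C@H](O)[C@@H]1O` has not been measured in this assay. It differs from compound 3 by thiophen-3-yl in place of furan-3-yl on an aromatic carbon, the same change, at the same place, as that from compound 1 to compound 2. Because that earlier step was a 1.2-fold higher number from compound 1 to compound 2 (0.09 log units; within the scatter), the step from compound 3 to compound 4 is expected to be of similar size, a 1.2-fold higher number from compound 3 to compound 4 (0.07 log units; within the scatter). On that basis compound 4 is estimated at 3200 nM, likely between 1500 nM and 7000 nM.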

Compound 4, half-maximal inhibitory concentration: 340 nM
Estimate against measurement, compound 4: 9.4-fold (0.97 log units) above, outside the stated range (below it).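

In this assay, the change from furan-3-yl to thiophen-3-yl did not carry over from the fluoro core to the chloro core, where it gave a 7.9-fold lower number from compound 3 to compound 4 (0.90 log units; beyond the scatter), and the two steps differ: the same change on two cores in this assay, a 1.2-fold higher number (0.09 log units; within the scatter) from compound 1 to compound 2 and a 7.9-fold lower number (0.90 log units; beyond the scatter) from compound 3 to compound 4, 9.8-fold (0.99 log units) apart, beyond the scatter of two such steps

The change from fluoro to chloro also depended on the group already present, giving a 1.6-fold higher number from compound 2 to compound 4 (0.21 log units; within the scatter) with thiophen-3-yl on the core, against a far larger step with furan-3-yl: the same change on two cores in this assay, a 16-fold higher number (1.20 log units; beyond the scatter) from compound 1 to compound 3 and a 1.6-fold higher number (0.21 log units; within the scatter) from compound 2 to compound 4, 9.8-fold (0.99 log units) apart, beyond the scatter of two such steps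

The two changes therefore do not add independently across these compounds, so a step measured on one core cannot safely be transferred to the other, but this rests on a single square of four compounds and does not show why the steps differ or how either change would behave on another core.

The compounds shown leave open whether this dependence extends to other groups in the same place, such as a phenyl ring or an amine. They also leave open what a methyl or a nitrile would do in place of the halogen.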